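Swapping 1H-pyrazol-4-yl for 1,3-oxazol-4-yl: working notes

The source may report more compounds than this note shows. Statements on the series, on what has been measured and on what is new or still open speak of the compounds shown alone.

In an ADME assay on the whole organism (Rattus norvegicus) for pharmacokinetics, at a dose of 1 mg/kg by the intravenous route (on this read-out higher numbers stand for fast clearance and lower numbers for slow clearance), compound 1 `O=C(c1cn[nH]c1)N1CCC(C(=O)N2N=CCC2c2ccccc2)CC1` gives 46 mL/min/kg. Compound 2 `N#Cc1cc(N2CCC(C(=O)N3N=CC[C@H]3c3cc(F)cc(F)c3)CC2)ncn1` gives 46 mL/min/kg, so compound 1 stands level with compound 2 within the scatter. Compound 3 `O=C(c1cocn1)N1CCC(C(=O)N2N=CCC2c2ccccc2)CC1` keeps the core of compound 1 and carries 1,3-oxazol-4-yl in place of 1H-pyrazol-4-yl on a carbonyl carbon. Going by the values given here, no measured pair isolates this change, so the data give no direct guide to its size. Among the compounds with values here, the only anchor is compound 1 at 46 mL/min/kg, and two compounds at one level suggest no direction. A step within the scatter of this assay is therefore expected, with no preferred direction. The estimate amounts to a 1.0-fold lower number from compound 1 to compound 3 (0.01 log units; within the scatter). For compound 3 the estimated clearance is 45 mL/min/kg, with an expected range of 25 mL/min/kg to 75 mL/min/kg.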

Compound 3, clearance: 58 mL/min/kg
The estimate for compound 3 lay 1.3-fold (0.11 log units) below the measured number; low and high end bracket the measured number.
By their numbers in this assay, from the lowest: compounds 1, 2 and 3 (each within the scatter of the next).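

In this assay, 1,3-oxazol-4-yl in place of 1H-pyrazol-4-yl on a carbonyl carbon gives a 1.3-fold higher number from compound 1 to compound 3 (0.10 log units; within the scatter), and this pair now isolates the change on the core of compound 1. At this position, going from a ring with 1 hydrogen-bond donor and 1 acceptor to one with 0 donors and 2 acceptors leaves the read-out within the scatter, so clearance in this pair does not depend measurably on which of the two rings is present. Nothing available bears on why the two rings read alike.

This single pair cannot show whether the swap would read the same on another core. It also leaves open how a group of a different kind on the same carbonyl carbon, such as a carboxylic acid or a primary amine on a longer chain, would read.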